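The source may hold more compounds than are shown below. What is called first, only, known or untested is meant among the compounds shown, and "the series" means these compounds.

Three compounds share one core and differ only in two aromatic substituents. In a functional assay on HT-29 cells (Homo sapiens) for cytotoxicity, read by MTT assay, with a stated time of 72 h (a higher number here means a weaker inhibitor, a lower number a stronger inhibitor), compound 1 `COc1ccc(-c2cc(C(=O)Nc3ccc(Oc4ccnc5cc(OCCCN6CCCCC6)c(OC)cc45)c(F)c3)c3ccccc3n2)cc1` gives 690 nM. Compound 2 `COc1cccc(-c2cc(C(=O)Nc3ccc(Oc4ccnc5cc(OCCCN6CCCCC6)c(OC)cc45)c(F)c3)c3ccccc3n2)c1` gives 1740 nM in this assay, and the step of a 2.5-fold higher number from compound 1 to compound 2 (0.40 log units; beyond the scatter) is beyond the scatter. Compound 3 `COc1cccc(-c2cc(C(=O)Nc3ccc(Oc4ccnc5cc(OCCCN6CCCCC6)c(OC)cc45)c(F)c3)c3cc(F)ccc3n2)c1` gives 2500 nM in this assay, the highest of the three numbers. The step of a 1.4-fold higher number from compound 2 to compound 3 (0.16 log units; within the scatter) stays within the scatter. Compound 4 `COc1ccc(-c2cc(C(=O)Nc3ccc(Oc4ccnc5cc(OCCCN6CCCCC6)c(OC)cc45)c(F)c3)c3cc(F)ccc3n2)cc1` is not yet measured and differs from compound 3 by 4-methoxyphenyl in place of 3-methoxyphenyl on an aromatic carbon. This is the reverse of the change measured as a 2.5-fold higher number from compound 1 to compound 2 (0.40 log units; beyond the scatter), so a lower number of similar size is expected for compound 4 in this assay, namely a 2.5-fold lower number from compound 3 to compound 4 (0.40 log units; beyond the scatter). Compound 4 is therefore estimated at 1000 nM, within a range from 500 nM to 2000 nM.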

Compound 4, half-maximal inhibitory concentration: 600 nM
Beside the measured number, compound 4's estimate is 1.7-fold (0.22 log units) above it, and the stated range covers the measured number.
By their numbers in this assay, from the lowest: compounds 4 and 1 (each within the scatter of the next); then compounds 2 and 3 (each within the scatter of the next).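

In this assay, 4-methoxyphenyl in place of 3-methoxyphenyl now also gives a lower number on the fluorinated core, a 4.2-fold lower number from compound 3 to compound 4 (0.62 log units; beyond the scatter), so the preference at this place is seen on two cores, with steps of similar size: the same change on two cores in this assay, a 2.5-fold higher number (0.40 log units; beyond the scatter) from compound 1 to compound 2 and a 4.2-fold higher number (0.62 log units; beyond the scatter) from compound 4 to compound 3, 1.7-fold (0.22 log units) apart, within the scatter of two such steps. Fluoro in place of hydrogen, tested here with 4-methoxyphenyl in place, gives a 1.2-fold lower number from compound 1 to compound 4 (0.06 log units; within the scatter), so it shows no clear effect with either methoxyphenyl group: the same change on two cores in this assay, a 1.4-fold higher number (0.16 log units; within the scatter) from compound 2 to compound 3 and a 1.2-fold lower number (0.06 log units; within the scatter) from compound 1 to compound 4, 1.7-fold (0.22 log units) apart, within the scatter of two such steps. Still open, going by these compounds, is whether 4-hydroxyphenyl or 4-aminophenyl at this place would match 4-methoxyphenyl, and what chloro in place of fluoro would do.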